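The source may hold more compounds than are shown below. What is called first, only, known or untested is meant among the compounds shown, and "the series" means these compounds.

Measured in an ADME assay on Vero cells (Chlorocebus sabaeus) for cytotoxicity, read by MTT assay; on this read-out lower numbers stand for higher toxicity in this test and higher numbers for lower toxicity in this test:
Compound 1 `Cn1nc(C(F)(F)F)cc1C(=O)Nc1ccc(S(=O)(=O)N2CCCCC2)cc1`: > 300000 nM, a limit
Compound 2 `Cn1nc(C(F)(F)F)cc1C(=O)Nc1ccc(S(=O)(=O)OC2CCCCC2)cc1`: > 300000 nM, a limit

Compound 2 offers only a limit and no number. Both measured compounds share one reading: the limit of > 300000 nM in this assay, at which 2 of the 2 values shown sit.

Compound 3 `Cn1nc(C(F)(F)F)cc1C(=O)Nc1ccc(S(=O)(=O)N2CCC(N)CC2)cc1` carries 4-aminopiperidin-1-yl in place of cyclohexyloxy on a sulfonyl sulfur.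

Among the measured compounds shown here, the only measured step is a step that the two limits leave unreadable from compound 1 to compound 2. It gives no size to carry over, and it shows no drop in this assay for either group tested on the sulfonyl sulfur. From the compounds shown here alone, neither measured compound carries 4-aminopiperidin-1-yl, so the new group remains untested. The expectation is therefore a small step or none, with room only toward lower numbers, meaning higher toxicity in this test. Compound 3 may well return the same limit as a result. The estimated change is an at least 1.5-fold lower number from compound 2 to compound 3 (0.17 log units; that floor lies within the scatter), and it is rough since it starts from a limit. For compound 3 the estimate is 200000 nM, with an expected range of 60000 nM to 300000 nM.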

Compound 3, half-maximal cytotoxic concentration: > 300000 nM
Compound 3: no number, only a limit; the forecaster's own chance of this, stated with the estimate: 55%; at least 1.5-fold (0.17 log units) between middle value and limit.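

Compound 1, compound 2 and compound 3 all return only a limit in this assay, so no step among them can be read: the limit of > 300000 nM in this assay, at which 3 of the 3 values shown sit.

The compounds shown leave open whether any group on the sulfonyl sulfur gives a number rather than a limit in this assay, and how piperidin-1-yl, cyclohexyloxy and 4-aminopiperidin-1-yl rank against one another.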